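This account rests on a few compounds, and the source may have more. Where it says the series, first, only, none or still open, it means among the compounds named here.

Working notes on the plasma binding series.

Compound 2 `CCNc1nccc(N2CC[C@H](NC(=O)Nc3ccc(Cl)c(C(F)(F)F)c3)C2)n1` gives 99.9% in an ADME assay on a cell-free system (plasma, Mus musculus) for protein binding. Compound 1 `CNc1nccc(N2CC[C@H](NC(=O)Nc3ccc(Cl)c(C(F)(F)F)c3)C2)n1` gives 99.8% in this assay, and the two sit together at one end of the three values: a 2.0-fold lower unbound fraction from compound 1 to compound 2 (0.30 log units; within the scatter). Compound 3 `CNc1nccc(N2CC[C@H](NC(=O)Nc3ccc(CN4CCCC4)c(C(F)(F)F)c3)C2)n1` gives 87.2%, far from both, with a 64-fold higher unbound fraction from compound 1 to compound 3 (1.81 log units; beyond the scatter).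

Compound 4 `O=C(Nc1ccc(Cl)c(C(F)(F)F)c1)N[C@H]1CCN(c2ccncn2)C1` has not been measured. It differs from compound 2 by hydrogen in place of ethylamino on an aromatic carbon, which cuts the substituent at the aromatic carbon between two ring nitrogen atoms down to bare hydrogen and removes one hydrogen-bond donor and one hydrogen-bond acceptor.

Going by the values given here, of the measured steps, only the step from compound 1 to compound 2 touches this part of the core, and there methyl in place of hydrogen on the saturated chain carbon gave a 2.0-fold lower unbound fraction from compound 1 to compound 2 (0.30 log units; within the scatter), within the scatter. The large step a 64-fold higher unbound fraction from compound 1 to compound 3 (1.81 log units; beyond the scatter) lies at the other aromatic ring and does not speak to this change. Nothing measured removes the whole amino group. Removing three heavy atoms goes in the direction opposite to the step from compound 1 to compound 2. For compound 4 this change is expected to raise the unbound fraction somewhat, a 4.0-fold higher unbound fraction from compound 2 to compound 4 (0.60 log units; beyond the scatter), though it may also stay within the scatter.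

Compound 4 is therefore expected to give 99.6% in this assay, between 99% and 99.9%.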

Compound 4, plasma protein binding: 99.3%
For compound 4 the middle estimate is 1.8-fold (0.24 log units) (unbound fraction) below the measured one; the measured number falls inside the stated range.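

In this assay the substituent on the aromatic carbon between two ring nitrogen atoms turns out to count: hydrogen in place of ethylamino gives a 7.0-fold higher unbound fraction from compound 2 to compound 4 (0.85 log units; beyond the scatter) and hydrogen in place of methylamino gives a 3.5-fold higher unbound fraction from compound 1 to compound 4 (0.54 log units; beyond the scatter) so the two removals read the same way. The earlier change at this substituent, a 2.0-fold lower unbound fraction from compound 1 to compound 2 (0.30 log units; within the scatter) stayed within the scatter, so a change in the amino chain alone showed nothing that could be told apart, whereas loss of the whole group shows a modest step. Both steps remain well short of a 64-fold higher unbound fraction from compound 1 to compound 3 (1.81 log units; beyond the scatter) and compound 4 still gives 99.3% in this assay so among the compounds shown this position moves the read-out only modestly.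

From the compounds shown here alone, whether a methoxy group, a dimethylamino group or a longer amine chain on this carbon would read like hydrogen or like methylamino stays open, as does whether the step holds when (pyrrolidin-1-yl)methyl stands in place of chloro on the other aromatic ring. No measurement at hand bears on the origin of these steps.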